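The source may hold more compounds than are shown below. What is called first, only, known or untested is meant among the compounds shown, and "the series" means these compounds.

Compound 2 `CCOC(=O)c1cnc(-c2cnc3ccccc3c2)nc1NN1C(=O)C=C(C)C1=O` carries a quinolin-3-yl group on the shared core. Within the data shown here, in a functional assay on Jurkat cells for inhibition of nuclear factor NF-kappa-B complex (Homo sapiens) (on this read-out higher numbers stand for weaker inhibition and lower numbers for stronger inhibition), compound 2 gives 6000 nM, the highest number among the two compounds measured so far. Its nearest neighbour is compound 1 `CCOC(=O)c1cnc(-c2cccs2)nc1NN1C(=O)C=C(C)C1=O`, which carries a thiophen-2-yl group at the same place and in this assay gives 20 nM. Among the measured compounds shown here, the single step measured so far, a 300-fold higher number from compound 1 to compound 2 (2.48 log units; beyond the scatter), shows that exchanging the five-membered thiophene ring for the two-ring quinoline went with a large loss of inhibitory strength.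

Compound 3 `CCOC(=O)c1cnc(-c2csc(C)n2)nc1NN1C(=O)C=C(C)C1=O` has not yet been measured. It differs from compound 2 by 2-methyl-1,3-thiazol-4-yl in place of quinolin-3-yl on an aromatic carbon. The entering group, like the thiophen-2-yl of compound 1, is a single five-membered aromatic ring, so this change runs in the opposite sense to that measured step. Compound 3 is therefore expected to show a step of a 100-fold lower number from compound 2 to compound 3 (2.00 log units; beyond the scatter) in this assay, with an estimated value of 60 nM and a range from 12 nM to 400 nM. This expectation rests on compound 1 with its value 20 nM and on the step of a 300-fold higher number from compound 1 to compound 2 (2.48 log units; beyond the scatter); the uncertainty is wide since no thiazole has been measured here.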

Compound 3, half-maximal inhibitory concentration: 8000 nM
Compound 3: the middle estimate sits 130-fold (2.12 log units) below what was measured; the whole stated range lies below it.
By their numbers in this assay, from the lowest: compound 1; then compounds 2 and 3 (each within the scatter of the next).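

In this assay, the change from a quinolin-3-yl group to a 2-methyl-1,3-thiazol-4-yl group gives a 1.3-fold higher number from compound 2 to compound 3 (0.12 log units; within the scatter), so replacing two six-membered aromatic rings with a single five-membered aromatic ring does not by itself change the read-out at this carbon. Compound 3 also carries a sulfur-containing five-membered aromatic ring, as compound 1 does, yet the exchange of thiophen-2-yl for 2-methyl-1,3-thiazol-4-yl gives a 400-fold higher number from compound 1 to compound 3 (2.60 log units; beyond the scatter), which shows that ring size alone does not account for the strong inhibition of compound 1. Among these compounds, of these three compounds, only the one with thiophen-2-yl is a strong inhibitor, so this position responds sharply even to a change from one five-membered aromatic ring to another, and no measurement at hand bears on what lies behind this.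

Going by these compounds, it remains open whether the methyl group or the ring nitrogen of the thiazole matters more, which a thiazol-4-yl group without the methyl or a 5-methylthiophen-2-yl group could help to separate. A further open question is whether a furan-2-yl or a plain phenyl group on this carbon would come close to compound 1, which gives 20 nM.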